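This account rests on a few compounds, and the source may have more. Where it says the series, first, only, none or still open, it means among the compounds named here.

Measured so far:
compound 1 `COc1ccc(-c2cc(C(=O)/C=C/c3cc(OC)c(OC)c(OC)c3)nc3cc(-c4ccccc4)nn23)cc1OC` — 15400 nM
compound 2 `COc1ccc(-c2cc(/C=C/C(=O)c3ccc(Cl)cc3)nc3cc(-c4ccccc4)nn23)cc1OC` — 15400 nM

Both compounds share the same core and differ in the enone-bearing side arm. In a functional assay on A549 cells (Homo sapiens) for antiproliferative activity, read by MTT assay, with a stated time of 24 h (a higher number here means a weaker inhibitor, a lower number a stronger inhibitor), compound 1 gives 15400 nM. In this assay compound 2 gives 15400 nM, level with compound 1 at the digits recorded; the two values sit within the scatter of each other, so no ordering between them is claimed.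

The next compound, compound 3 `COc1ccc(/C=C/C(=O)c2cc(-c3ccc(OC)c(OC)c3)n3nc(-c4ccccc4)cc3n2)cc1`, is derived from compound 2 by the change ((2-(4-methoxyphenyl)ethenyl)carbonyl in place of 2-((4-chlorophenyl)carbonyl)ethenyl on an aromatic carbon). The (2-(4-methoxyphenyl)ethenyl)carbonyl group thus enters in place of 2-((4-chlorophenyl)carbonyl)ethenyl, on an aromatic carbon of the six-membered ring with two nitrogen atoms in the fused system.

Going by the values given here, no measured pair here shows what a change of this kind does. Among the compounds with values here, the only information is that compound 1 and compound 2, with different enone arms, give the same value in this assay. On that basis the step is expected to be no more than the scatter, in no set direction, with compound 3 expected at a 1.0-fold lower number from compound 2 to compound 3 (0.01 log units; within the scatter) relative to compound 2. For compound 3 the estimate in this assay is 15000 nM, with a range from 5000 nM to 45000 nM.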

Compound 3, half-maximal inhibitory concentration: 19300 nM
The estimate for compound 3 lay 1.3-fold (0.11 log units) below the measured number; measured number inside the range.
By their numbers in this assay, from the lowest: compounds 1, 2 and 3 (each within the scatter of the next).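

In this assay, replacing 2-((4-chlorophenyl)carbonyl)ethenyl with (2-(4-methoxyphenyl)ethenyl)carbonyl on the aromatic carbon next to the ring nitrogen gives a 1.3-fold higher number from compound 2 to compound 3 (0.10 log units; within the scatter) and so does not separate the two compounds; this aromatic carbon tolerates the exchange of these two arms without a readable shift in this cell assay. Going by these compounds alone, the second step is the first single-place reading on the aryl ring at the end of the arm: 4-methoxyphenyl in place of 3,4,5-trimethoxyphenyl gives a 1.3-fold higher number from compound 1 to compound 3 (0.10 log units; within the scatter) and likewise stays inside the scatter, so the number of methoxy groups on that ring, one against three, makes no readable difference in this pair. No other measurement on these compounds accompanies these values, and nothing can be said about why the steps are this small.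

On these data alone, the 3,4-dimethoxyphenyl and phenyl groups are identical in all three compounds, so what each contributes remains open. Also open, as far as these compounds go, is whether an amine or a carboxylic acid on the aryl ring of the arm, or a longer chain in place of the enone, would give a step beyond the scatter.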